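From Benzylsulfanyl to Benzylsulfonyl: An Untested Analogue

The source may hold more compounds than are shown below. What is called first, only, known or untested is meant among the compounds shown, and "the series" means these compounds.

Compound 1 `CCCSc1nnc(COc2cc(C)c3c(C)cc(=O)oc3c2)o1` and compound 2 `Cc1cc(OCc2nnc(SCc3ccccc3)o2)cc2oc(=O)cc(C)c12` share one core and differ by phenyl in place of ethyl on a saturated chain carbon bound to a sulfur. In a functional assay on MCF7 cells (Homo sapiens) for antiproliferative activity, read by MTT assay, with a stated time of 24 h (a lower number here means a stronger inhibitor, a higher number a weaker inhibitor), compound 1 gives only a limit, > 100000 nM. In this assay compound 2 likewise gives only a limit, > 100000 nM. The step that the two limits leave unreadable from compound 1 to compound 2 therefore cannot be read, and the limit of > 100000 nM in this assay, at which 2 of the 2 values shown sit, is all the evidence available. Compound 3 `Cc1cc(OCc2nnc(S(=O)(=O)Cc3ccccc3)o2)cc2oc(=O)cc(C)c12` carries benzylsulfonyl in place of benzylsulfanyl on an aromatic carbon. Going by the values given here, no measured step bears on this change, so no step beyond the scatter is expected in this assay. The expected step that the limit leaves unreadable from compound 2 to compound 3 rests on compound 2 alone. Compound 3 is estimated at 150000 nM, between 30000 nM and 1000000 nM.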

Compound 3, half-maximal inhibitory concentration: 38600 nM
Beside the measured number, compound 3's estimate is 3.9-fold (0.59 log units) above it; low and high end bracket the measured number.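

Going by these compounds alone, at this aromatic carbon, benzylsulfonyl in place of benzylsulfanyl gives an at least 2.5-fold lower number from compound 2 to compound 3 (0.41 log units; beyond the scatter), the first readable change in this assay. Benzylsulfonyl in place of propylsulfanyl gives an at least 2.5-fold lower number from compound 1 to compound 3 (0.41 log units; beyond the scatter). Both steps remain open-ended, and the step between compound 1 and compound 2 cannot be read, because both sulfanyl compounds sit at a limit: the limit of > 100000 nM in this assay, at which 2 of the 3 values shown sit.

The compounds shown leave open whether propylsulfonyl at this carbon would also give a readable number, or whether the benzyl part is needed as well. They also leave open how a sulfinyl group or an amine would compare there.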